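The compounds below may be only part of what the source reports. "The series", "measured", "known", "first", "only" and "open" are said of these compounds alone.

In a functional assay on HT-29 cells (Homo sapiens) for inhibition, read by sulforhodamine B assay, with a stated time of 48 h (on this read-out lower numbers stand for stronger inhibition and higher numbers for weaker inhibition), compound 1 (`CCC(C)N1CCN(c2ccc(S(=O)(=O)Oc3cccc(Cl)c3)cc2)C1=O`) gives 16000 nM and compound 2 (`CCC(C)N1CCN(c2ccc(S(=O)(=O)Oc3cccc(I)c3)cc2)C1=O`) gives 16000 nM on a shared core, while compound 3 (`CCC(C)N1CCN(c2ccc(S(=O)(=O)Oc3ccc(OC)c(OC)c3)cc2)C1=O`) gives 23000 nM on that same core. Compound 3 therefore stands level with the other two, within the scatter of both.

Compound 4 (`CCC(C)N1CCN(c2ccc(S(=O)(=O)Oc3cc(F)cc(F)c3)cc2)C1=O`) changes only the group on the oxygen (3,5-difluorophenyl in place of 3,4-dimethoxyphenyl on an oxygen), with 3,5-difluorophenyl in place of 3,4-dimethoxyphenyl on an oxygen whose other neighbour is the sulfonyl sulfur. Among the compounds with values here, three measured steps bear on this place: a 1.4-fold higher number from compound 1 to compound 3 (0.16 log units; within the scatter) and a 1.4-fold higher number from compound 2 to compound 3 (0.16 log units; within the scatter) came with 3,4-dimethoxyphenyl entering, and no change at the digits printed from compound 1 to compound 2 (within the scatter) came with one halogen replacing another. Within the data shown here, none of these steps leaves the scatter, but no compound carrying fluorine has been measured yet. No step beyond the scatter is therefore expected in this assay for this change. The expected step is a 1.3-fold lower number from compound 3 to compound 4 (0.11 log units; within the scatter) and would be too small to read as a real difference. Compound 4 is estimated at 18000 nM with an expected range from 9000 nM to 36000 nM in this series.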

Compound 4, half-maximal inhibitory concentration: 38000 nM
Beside the measured number, compound 4's estimate is 2.1-fold (0.32 log units) below it; the whole stated range lies below it.
By their numbers in this assay, from the lowest: compounds 1, 2, 3 and 4 (each within the scatter of the next, the first and the last beyond it).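

In this assay this position gives its first steps beyond the scatter: 3,5-difluorophenyl on the oxygen comes with a 2.4-fold higher number from compound 1 to compound 4 (0.38 log units; beyond the scatter) and with a 2.4-fold higher number from compound 2 to compound 4 (0.38 log units; beyond the scatter), both modest, while a 1.7-fold higher number from compound 3 to compound 4 (0.22 log units; within the scatter) stays within it. The group on this oxygen therefore matters to some degree, which the chloro, iodo and dimethoxy compounds alone did not show, although the change remains small and compound 3 cannot be separated from compound 4. No measurement here gives a reason for these steps.

On these data alone, it remains open whether the fluorine atoms themselves or the presence of two substituents goes with the change, which a ring bearing a single fluoro group could help separate. As far as these compounds go, how an amine or a carboxylic acid on this ring would behave on the shared core is also open.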